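This account rests on a few compounds, and the source may have more. Where it says the series, first, only, none or still open, it means among the compounds named here.

Compound 2 `COc1ccc(/C=C/C(=O)NS(=O)(=O)c2ccc(C)cc2)cc1` stands with the higher of the two numbers in a functional assay on B16-F10 cells (Mus musculus) for antiproliferative activity, read by ELISA and MTT assay, with a stated time of 48 h (a higher number here means a weaker inhibitor, a lower number a stronger inhibitor), where compound 2 gives 12.2 ug/mL while compound 1 `O=C(/C=C/c1ccc(Cl)cc1)NS(=O)(=O)c1ccc(F)cc1` gives 2 ug/mL, a gap beyond the scatter. Compound 3 `COc1ccc(/C=C/C(=O)NS(=O)(=O)c2ccc(F)cc2)cc1` differs from compound 2 by fluoro in place of methyl on an aromatic carbon. Among the compounds with values here, no measured pair shows this change on its own, and compound 1 differs from compound 2 in more than one place, so its lower number cannot be tied to the fluoro alone. A modest step toward a lower number is expected, a 1.5-fold lower number from compound 2 to compound 3 (0.18 log units; within the scatter). Compound 3 is therefore estimated to give 8 ug/mL, with a range from 3 ug/mL to 20 ug/mL.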

Compound 3, half-maximal inhibitory concentration: 5.1 ug/mL
Compound 3: middle estimate off by 1.6-fold (0.20 log units), on the high side, within the range that was stated.
By their numbers in this assay, from the lowest: compound 1; then compound 3; then compound 2.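

In this assay, fluoro in place of methyl on the aromatic carbon para to a large group gives a 2.4-fold lower number from compound 2 to compound 3 (0.38 log units; beyond the scatter) and so shows that this one swap alone moves the number, which the gap to compound 1 could not show. With the 4-fluorophenyl group kept, methoxy in place of chloro gives a 2.6-fold higher number from compound 1 to compound 3 (0.41 log units; beyond the scatter) and separates a second single change. No measurement at hand offers a reason for either step. Still open, as far as these compounds go, is how an amine or trifluoromethyl would fare in place of fluoro, and whether the fluoro step holds alongside chloro.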